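This account rests on a few compounds, and the source may have more. Where it says the series, first, only, none or still open, it means among the compounds named here.

Three compounds have been measured in a functional assay on U-937 cells (Homo sapiens) for antiproliferative activity, read by CCK-8 assay, with a stated time of 24 h; on this read-out higher numbers stand for weaker inhibition and lower numbers for stronger inhibition:

Compound 1, `CCN(CC)Cc1ccc2nc(NC(=O)N/N=C/c3ccccn3)sc2c1`, gives 24800 nM.
Compound 2, `CCN(CC)Cc1ccc2nc(NC(=O)N/N=C(\C)c3cnccn3)sc2c1`, gives only a limit of the assay, > 40000 nM.
Compound 3, `CC1CCN(Cc2ccc3nc(NC(=O)N/N=C/c4ccccn4)sc3c2)CC1`, gives 21500 nM.

Compound 1 and compound 3 differ only in the group on the side chain, diethylamino against 4-methylpiperidin-1-yl, and the step between them is a 1.2-fold lower number from compound 1 to compound 3 (0.06 log units; within the scatter); the two numbers sit together and no order between them can be read. From compound 1 to compound 2 the change is a group of 9 heavy atoms (6 carbon, 3 nitrogen; one six-membered aromatic ring with 2 hetero atoms) in place of a group of 8 heavy atoms (6 carbon, 2 nitrogen; one six-membered aromatic ring with 1 hetero atom), on an amide-type nitrogen. The step is an at least 1.6-fold higher number from compound 1 to compound 2 (0.20 log units; that floor lies within the scatter), and since the value of compound 2 is a limit, (the limit of > 40000 nM in this assay, at which 1 of the 3 values shown sits), only a floor for this step is known.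

Compound 4, `C/C(=N\NC(=O)Nc1nc2ccc(CN3CCC(C)CC3)cc2s1)c1cnccn1`, has not yet been measured in this assay. Its difference from compound 3 is a group of 9 heavy atoms (6 carbon, 3 nitrogen; one six-membered aromatic ring with 2 hetero atoms) in place of a group of 8 heavy atoms (6 carbon, 2 nitrogen; one six-membered aromatic ring with 1 hetero atom), on an amide-type nitrogen, the same change as from compound 1 to compound 2, made at the same place. The two cores differ as follows: 4-methylpiperidin-1-yl in place of diethylamino on a saturated chain carbon bound to an aromatic carbon.

Compound 3 starts from a number close to that of compound 1, and the same change took compound 1 to a limit. The expected step for compound 4 is therefore a 2.1-fold higher number from compound 3 to compound 4 (0.32 log units; beyond the scatter), and a limit rather than a number is the more likely outcome. The estimate for compound 4 is 45000 nM, with a range from 25000 nM to 90000 nM.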

Compound 4, half-maximal inhibitory concentration: > 40000 nM
Compound 4: only a limit was reported; the forecaster's own chance of this, stated with the estimate: 60%; the middle value is on the limit's open side.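

Placed on the core of compound 3, the change on the amide-type nitrogen gives an at least 1.8-fold higher number from compound 3 to compound 4 (0.26 log units; that floor lies within the scatter) in this assay, and only a floor is known for this step because compound 4 gives a limit and not a number: the limit of > 40000 nM in this assay, at which 2 of the 4 values shown sit. Carried from one core to the other, the change ends at a limit both times, which fits a change that carries over, but it does not show that the two steps have the same size or that either lies beyond the usual scatter: the same change on two cores in this assay, an at least 1.6-fold higher number (0.20 log units; that floor lies within the scatter) from compound 1 to compound 2 and an at least 1.8-fold higher number (0.26 log units; that floor lies within the scatter) from compound 3 to compound 4; the limit leaves it open whether they differ. The step from compound 2 to compound 4 cannot be read, so these compounds do not show whether 4-methylpiperidin-1-yl and diethylamino still give different or similar numbers once the new group is in place.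

The entering and leaving groups differ in more than one feature, and the compounds shown do not separate which part goes with the higher number. Also open, going by these compounds, is how another amine on the side chain, such as dimethylamino or a longer dialkylamino chain, would behave with either group on the amide-type nitrogen.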